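The source may report more compounds than this note shows. Statements on the series, on what has been measured and on what is new or still open speak of the compounds shown alone.

Measured compounds:
- Compound 1, `COc1ccc2[nH]cc(C(=O)/C(C#N)=C/C=C(\Cl)c3ccc(OC)c(OC)c3)c2c1`: 44900 nM in a functional assay on MCF7 cells (Homo sapiens) for cytotoxicity, read by sulforhodamine B assay, with a stated time of 48 h; on this read-out lower numbers stand for stronger inhibition of growth and higher numbers for weaker inhibition of growth
- Compound 2, `COc1ccc2[nH]cc(C(=O)/C(C#N)=C/C=C(\Cl)c3ccc(Br)cc3)c2c1`: 79900 nM in this assay

Among the two measured compounds, compound 1 holds the lowest number in this assay, but its neighbour compound 2 sits only a 1.8-fold higher number from compound 1 to compound 2 (0.25 log units; within the scatter) away, a gap within the scatter, so no order between them is established.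

Compound 3, `COc1ccc(/C(Cl)=C/C=C(\C#N)C(=O)c2c[nH]c3ccccc23)cc1OC`, has not yet been measured in this assay. It differs from compound 1 by hydrogen in place of methoxy on an aromatic carbon, a change on the shared core rather than on the chlorine-bearing chain carbon. For the measured compounds named here, the only measured step, from compound 1 to compound 2, concerns the aryl group on that chain carbon and therefore does not bear directly on the change to compound 3; it shows only that a substitution elsewhere in the molecule left the number within the scatter. Going by the values given here, the data give no step at the site altered in compound 3. On this basis the expectation is a step of a 1.0-fold higher number from compound 1 to compound 3 (0.00 log units; within the scatter) from compound 1 to compound 3, nothing beyond the scatter. Compound 3 is therefore estimated at 45000 nM in this assay, with a range of 15000 nM to 135000 nM.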

Compound 3, concentration for 50% growth inhibition: 44200 nM
Compound 3: the middle estimate sits 1.0-fold (0.01 log units) above what was measured; the range from low to high includes it.
By their numbers in this assay, from the lowest: compounds 3, 1 and 2 (each within the scatter of the next).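

Taking methoxy off the aromatic carbon of the shared core and leaving hydrogen in its place gives a 1.0-fold lower number from compound 1 to compound 3 (0.01 log units; within the scatter) in this assay and this is the first reading at this position, since the earlier pair differed only in the aryl group on the chlorine-bearing chain carbon. For the compounds shown here, on the aryl background of compound 1, then, the methoxy at this place on the core, the one group that leaves here, can go without the number in this read-out moving beyond the scatter, so compound 3 reads the same as compound 1 within that scatter. No evidence at hand explains this result or says anything further about what the methoxy does at this position.

The compounds shown cover only methoxy and hydrogen at this place, so it remains open whether a hydroxyl, an amine, a carboxylic acid or a longer alkoxy chain would leave the number within the scatter as well. They also leave open whether hydrogen in place of methoxy would read the same alongside the 4-bromophenyl group of compound 2.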